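This account rests on a few compounds, and the source may have more. Where it says the series, first, only, none or still open, it means among the compounds named here.

Measured in a functional assay on M21 cells (Homo sapiens) for inhibition, read by sulforhodamine B assay, with a stated time of 48 h; a higher number here means a weaker inhibitor of growth, a lower number a stronger inhibitor of growth:
- compound 1 `c1cc(OC2CCCCC2)ccc1NC1=NCCO1`: 20800 nM
- compound 2 `O=C(CCl)NC(=O)Nc1ccc(OC2CCCCC2)cc1`: 5000 nM
- compound 3 `O=C(CCl)NC(=O)Nc1ccc(OC2CCCCCC2)cc1`: 5000 nM

Compound 2 stands level with compound 3, and these two share the lowest number of the three. The gap to the remaining compound is a 4.2-fold lower number from compound 1 to compound 2 (0.62 log units; beyond the scatter).

Compound 4 `Cc1ccc(NC(=O)NC(=O)CCl)cc1` carries methyl in place of cyclohexyloxy on an aromatic carbon.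

Among the measured compounds shown here, two measured steps bear on this only in part. Enlarging the ring on the oxygen changed nothing: no change at the digits printed from compound 2 to compound 3 (within the scatter). That step keeps a large ring in place, whereas compound 4 has no ring there at all, so it sets no size for this change. The other step, a 4.2-fold lower number from compound 1 to compound 2 (0.62 log units; beyond the scatter), concerns the opposite end of the molecule. For the measured compounds named here, no measured compound tests the loss of the ring directly, so the expectation is uncertain. A modest move to a higher number in this assay, meaning weaker inhibition, is expected: a 4.0-fold higher number from compound 2 to compound 4 (0.60 log units; beyond the scatter). For compound 4 the estimated value is 20000 nM, with an expected range of 7000 nM to 60000 nM.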

Compound 4, concentration for 50% growth inhibition: 4900 nM
Compound 4: middle estimate off by 4.1-fold (0.61 log units), on the high side, and the stated range ends above it.
By their numbers in this assay, from the lowest: compounds 4, 2 and 3 (each within the scatter of the next); then compound 1.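

In this assay, the cyclohexyloxy group gives way to methyl on the aromatic carbon with a 1.0-fold lower number from compound 2 to compound 4 (0.01 log units; within the scatter), so the ring on the oxygen, and the oxygen itself, are not needed to hold this level of growth inhibition. Together with no change at the digits printed from compound 2 to compound 3 (within the scatter), this shows that three quite different groups at this place leave the number within the scatter. These groups are the cyclohexyl ether, the cycloheptyl ether and methyl. No available data explain this flat response at the position.

On these data alone, whether an amine, a carboxylic acid or a longer chain on this aromatic carbon would also stay level remains open. As far as these compounds go, it is also open whether methyl would behave in the same way with the five-membered ring of compound 1 at the other end of the molecule.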